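Varying the amide substituent on a thyrotropin receptor agonist series

The source may report more compounds than this note shows. Statements on the series, on what has been measured and on what is new or still open speak of the compounds shown alone.

Measured compounds:
compound 1, `COc1cccc(-c2nc(SC)nc3sc(C(=O)NCc4ccccc4)c(N)c23)c1`, 3%
compound 2, `CCOC(=O)c1sc2nc(SC)nc(-c3cccc(OC)c3)c2c1N`, 1.5%
compound 3, `COc1cccc(-c2nc(SC)nc3sc(C(=O)NN)c(N)c23)c1`, 6.1%

In a functional assay on HEK293 cells for agonist activity at Thyrotropin receptor (Homo sapiens), read by cAMP accumulation (a lower number here means a smaller maximal response, a higher number a larger maximal response), compound 3 gives 6.1%. Compound 1 and compound 2 share its core and differ only at the carbonyl carbon; the numbers of all three lie within the usual scatter of one another, as a number 3.1 percentage points higher from compound 1 to compound 3 (within the scatter) and a number 4.6 percentage points higher from compound 2 to compound 3 (within the scatter) show, so no one of them can be set apart from the others. Compound 4 is `COc1cccc(-c2nc(SC)nc3sc(C(=O)NCCO)c(N)c23)c1`. It differs from compound 3 as follows: 2-hydroxyethyl in place of amino on an amide-type nitrogen. Among the measured compounds shown here, the steps that bear on this change are those that altered the same position: a number 1.5 percentage points lower from compound 1 to compound 2 (within the scatter), a number 3.1 percentage points higher from compound 1 to compound 3 (within the scatter) and a number 4.6 percentage points higher from compound 2 to compound 3 (within the scatter), all within the scatter. Since benzylamino, ethoxy and aminoamino at the carbonyl carbon left the maximal response close to zero, the expectation for compound 4 is a step of a number 2.1 percentage points lower from compound 3 to compound 4 (within the scatter), that is, none beyond the scatter. Compound 4 is therefore estimated at 4% in this assay, within a range of 0% to 12%.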

Compound 4, largest response reached (reported as efficacy), in percent of the reference or control that the assay uses: 2.9%
Compound 4: the middle estimate sits 1.1 percentage points above what was measured; the measured number falls inside the stated range.
By their numbers in this assay, from the lowest: compounds 2, 4, 1 and 3 (each within the scatter of the next).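

In this assay, 2-hydroxyethyl in place of amino on the amide-type nitrogen gives a number 3.2 percentage points lower from compound 3 to compound 4 (within the scatter). Against the ester, (2-hydroxyethyl)amino in place of ethoxy on the carbonyl carbon gives a number 1.4 percentage points higher from compound 2 to compound 4 (within the scatter), and against the benzyl amide, hydroxymethyl in place of phenyl on the saturated chain carbon gives a number 0.1 percentage points lower from compound 1 to compound 4 (within the scatter). A substituent ending in a hydroxyl group therefore joins benzylamino, ethoxy and aminoamino at the carbonyl carbon, with all four compounds within the scatter of one another, so this position has not yet separated any pair of compounds.

Going by these compounds, whether a carboxylic acid, a tertiary amide or a longer chain at the carbonyl carbon would move the maximal response beyond the scatter stays open. Nothing available explains why these four substituents cannot be told apart.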